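The source may hold more compounds than are shown below. What is called first, only, known or untested is meant among the compounds shown, and "the series" means these compounds.

Three compounds share one core and differ only in the group carried on the outer phenyl ring. Compound 1 `CCCS(=O)(=O)Nc1ccc(F)c(C(=O)c2n[nH]c3ncc(-c4ccc(S(=O)(=O)NCC)cc4)cc23)c1F` gives 41% in an assay for binding affinity to dual specificity mitogen-activated protein kinase kinase 4 (Homo sapiens), read by KINOMEscan, tested at 10 nM; a higher number here means a weaker effect of the compound at the concentration tested, a lower number a stronger effect. Compound 2 `CCCS(=O)(=O)Nc1ccc(F)c(C(=O)c2n[nH]c3ncc(-c4ccc(S(=O)(=O)NC(C)=O)cc4)cc23)c1F` gives 0.5%, and compound 3 `CCCS(=O)(=O)Nc1ccc(F)c(C(=O)c2n[nH]c3ncc(-c4ccc(-c5nnn[nH]5)cc4)cc23)c1F` gives 1.1%. Compound 3 therefore sits far from compound 1, the step being a number 39.9 percentage points lower from compound 1 to compound 3 (beyond the scatter), while the step of a number 0.6 percentage points higher from compound 2 to compound 3 (within the scatter) lies within the scatter, so compounds 2 and 3 cannot be told apart here. Compound 4 `CCCS(=O)(=O)Nc1ccc(F)c(C(=O)c2n[nH]c3ncc(-c4ccc(C(N)=O)cc4)cc23)c1F` has not yet been measured. It differs from compound 3 in one place: carbamoyl in place of 1H-tetrazol-5-yl on an aromatic carbon. For the measured compounds named here, no measured step involves a carbamoyl group, so the only guide is that the group on this carbon has already been swapped twice: a number 40.5 percentage points lower from compound 1 to compound 2 (beyond the scatter) was large, yet a number 0.6 percentage points higher from compound 2 to compound 3 (within the scatter) was small. The change to compound 4 is a third, different swap, so the expected step of a number 13.9 percentage points higher from compound 3 to compound 4 (beyond the scatter) is uncertain and is taken as a moderate rise. Compound 4 is estimated at 15%, between 1% and 60%.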

Compound 4, a percentage reported as activity, at one concentration (the size of the read-out at that concentration, not a potency): 4%
Beside the measured number, compound 4's estimate is 11 percentage points above it; the measured number falls inside the stated range.
By their numbers in this assay, from the lowest: compounds 2, 3 and 4 (each within the scatter of the next); then compound 1.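

In this assay, the swap to carbamoyl gives a number 2.9 percentage points higher from compound 3 to compound 4 (within the scatter) and a number 3.5 percentage points higher from compound 2 to compound 4 (within the scatter), so at this position, para to a large group, carbamoyl cannot be told apart from 1H-tetrazol-5-yl or acetylsulfamoyl. The result adds that a low number does not need a group as large as those two: carbamoyl has only 3 heavy atoms and no ring, and among the four compounds only compound 1 stands apart, with a number 37 percentage points lower from compound 1 to compound 4 (beyond the scatter). No measurements are available to explain why these groups behave alike.

On these data alone, it remains open whether an ethyl group on the carbamoyl nitrogen would lift the number, as the ethylsulfamoyl group of compound 1 stands high against the acetylsulfamoyl group of compound 2. As far as these compounds go, how a carboxylic acid or a plain amine on this carbon would read is also open.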